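The source may hold more compounds than are shown below. What is called first, only, known or untested is meant among the compounds shown, and "the series" means these compounds.

Compound 1 `Cc1cc(-c2ccccc2NCC2=NCCN2)on1`: < 100000 nM
Compound 2 `Cc1nc(-c2ccccc2NCC2=NCCN2)no1`: < 5020 nM

In a functional assay for activation of Alpha-1D adrenergic receptor (Homo sapiens) (on this read-out higher numbers stand for an effect only at larger amounts of compound and lower numbers for an effect already at smaller amounts), compound 1 gives < 100000 nM, which is a limit of the assay rather than a number. Compound 2 gives < 5020 nM, also a limit only. The step that the two limits leave unreadable from compound 1 to compound 2 cannot be read because the limit of < 100000 nM in this assay, at which 1 of the 2 values shown sits, and the limit of < 5020 nM in this assay, at which 1 of the 2 values shown sits, are both limits. Compound 3 `Cc1ccc(-c2ccccc2NCC2=NCCN2)o1` differs from compound 2 by 5-methylfuran-2-yl in place of 5-methyl-1,2,4-oxadiazol-3-yl on an aromatic carbon. Going by the values given here, the only measured step, from compound 1 to compound 2, bears on this change, but its size is unknown, so no direction beyond the scatter is expected in this assay. The estimate for compound 3 is 3000 nM, in a range from 300 nM to 30000 nM. This estimate means an expected step that the limit leaves unreadable from compound 2 to compound 3.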

Compound 3, half-maximal effective concentration: < 2000 nM
Compound 3: a limit, no number (the forecaster's own chance of this, stated with the estimate: 50%); middle value at least 1.5-fold (0.17 log units) from the limit.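

In this assay compound 3 gives < 2000 nM, a limit and not a number, so its steps from compound 1 and compound 2 cannot be read. The compounds shown leave open whether these three groups differ in effect at all.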